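The compounds below may be only part of what the source reports. "The series", "measured", "known", "first", "only" and "open" are said of these compounds alone.

In a functional assay on L1210 cells (Mus musculus) for antiproliferative activity (on this read-out higher numbers stand for higher potency (the scale is a negative logarithm) and lower numbers for lower potency), the compounds measured so far stand as follows:

compound 1, `CCN(C)/N=N/c1ccc(C(N)=O)cc1`, gives 3.66
compound 2, `CN(C)/N=N/c1ccccc1C(N)=O`, gives 3.31
compound 3, `CCCN(C)/N=N/c1ccccc1C(N)=O`, gives 3.26

Compound 2 and compound 3 share one core and differ only by ethyl in place of hydrogen on a saturated chain carbon bound to an amine nitrogen. That change made the step of a number 0.05 log units lower from compound 2 to compound 3 (within the scatter). Compound 1 is built on a core that differs from the core of compound 2; the difference between the two cores is not broken down here. Its number is the highest of the three, and its steps to compound 2 and to compound 3 lie beyond the scatter.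

Compound 4, `CCCCN(C)/N=N/c1ccc(C(N)=O)cc1`, is not yet measured. It differs from compound 1 by ethyl in place of hydrogen on a saturated chain carbon, two bonds along the chain from an amine nitrogen. Among the compounds with values here, this is the same kind of change as the one from compound 2 to compound 3, but not the same: there the carbon is bound to an amine nitrogen, here it is two bonds along the chain from an amine nitrogen. Within the data shown here, the step of a number 0.06 log units lower from compound 1 to compound 4 (within the scatter) is expected to be small, because the only step of this kind seen so far, a number 0.05 log units lower from compound 2 to compound 3 (within the scatter), stayed within the scatter. Compound 4 is therefore estimated at 3.6, with a likely range from 3.2 to 4.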

Compound 4, logarithm of the reciprocal of the active concentration, log(1/C): 3.47
Compound 4: middle estimate off by 0.13 log units, on the high side; the range from low to high includes it.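

In this assay, the new step is a number 0.19 log units lower from compound 1 to compound 4 (within the scatter). Set beside the earlier step, it shows that this change carried over from one core to the other with no difference that stands clear of the scatter: the same change on two cores in this assay, a number 0.05 log units lower (within the scatter) from compound 2 to compound 3 and a number 0.19 log units lower (within the scatter) from compound 1 to compound 4, 0.14 log units apart, within the scatter of two such steps. Within the data shown here, this rests on only two pairs on two cores, so it shows that the step stayed small on both, but it does not show that the two cores respond identically, and a small true difference could be hidden in the scatter, nor does it show that the step would stay small on a third core.

The compounds shown leave open whether a chain longer than butyl would also give a step this small. They also leave open what would happen if the chain carried a polar group such as an amine or a carboxylic acid, which could behave quite differently from the plain carbon chains compared here.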